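The source may report more compounds than this note shows. Statements on the series, on what has been measured and on what is new or still open speak of the compounds shown alone.

Compound 1 `O=C(CSc1ncccn1)N1N=C(c2cc3ccccc3oc2=O)C[C@@H]1c1ccc(C(F)(F)F)cc1`: 4750 nM
Compound 2 `CC1=NN(C(=O)CSc2ccccc2)[C@@H](c2cc(Br)cc(Br)c2O)C1`: 10400 nM

In a functional assay on HepG2 cells (Homo sapiens) for cytotoxicity, read by MTT assay, with a stated time of 48 h (on this read-out lower numbers stand for stronger inhibition and higher numbers for weaker inhibition), compound 1 gives 4750 nM, the lower of the two numbers shown, and compound 2 gives 10400 nM, a gap that lies beyond the usual scatter. Within the data shown here, the two share no single-point change, so no measured step is available. Compound 3 `O=C(CSc1ccc(Br)cc1)N1N=C(c2cc3ccccc3oc2=O)C[C@@H]1c1ccc(C(F)(F)F)cc1` differs from compound 1 by 4-bromophenyl in place of pyrimidin-2-yl on a sulfur. Nothing measured here tests this exchange, and in this assay the step is expected to be small, staying within the scatter in either direction. Compound 3 is therefore estimated at 4500 nM, with a range from 1500 nM to 13000 nM. This amounts to an expected step of a 1.1-fold lower number from compound 1 to compound 3 (0.02 log units; within the scatter).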

Compound 3, half-maximal inhibitory concentration: 12700 nM
Beside the measured number, compound 3's estimate is 2.8-fold (0.45 log units) below it, within the range that was stated.
By their numbers in this assay, from the lowest: compound 1; then compounds 2 and 3 (each within the scatter of the next).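

In this assay, 4-bromophenyl in place of pyrimidin-2-yl on the sulfur gives a 2.7-fold higher number from compound 1 to compound 3 (0.43 log units; beyond the scatter), the first single-point step available here. It is modest but beyond the scatter, so this position does respond to the ring it carries, and in this pair the pyrimidin-2-yl compound has the lower number. Nothing available speaks to the reason for this step.

The exchange swaps the ring nitrogens and adds the bromine at once, leaving their separate contributions open. On these data alone, how pyridin-2-yl or 4-aminophenyl on this sulfur would read also remains open.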